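Methoxy on compound 1: what size of step to expect

This account rests on a few compounds, and the source may have more. Where it says the series, first, only, none or still open, it means among the compounds named here.

Compound 1 `O=C1C=CCC/C1=C\C=C\c1ccccc1`: 4200 nM
Compound 2 `O=C1C=CCC/C1=C\C=C\c1ccc([N+](=O)[O-])cc1`: 4200 nM

Within the data shown here, in a functional assay on Bel-7402 cells (Homo sapiens) for cytotoxicity, read by MTT assay, with a stated time of 72 h (a higher number here means a weaker inhibitor, a lower number a stronger inhibitor), compound 1 gives 4200 nM, level with compound 2, the only other compound measured so far. The compound to be tested next is compound 3 `COc1ccccc1/C=C/C=C1\CCC=CC1=O`. Its structural change from compound 1 is methoxy in place of hydrogen on an aromatic carbon, which means methoxy in place of hydrogen on an aromatic carbon, ortho to a large group.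

Among the measured compounds shown here, the only measured step that bears on this is no change at the digits printed from compound 1 to compound 2 (within the scatter), where nitro took the place of hydrogen on an aromatic carbon. That is a different group, so it is a loose guide, and the data give no direction for methoxy. No step beyond the scatter is therefore expected in this assay.

The estimated value for compound 3 is 4000 nM, with an expected range from 1500 nM to 10000 nM. This expectation amounts to a 1.1-fold lower number from compound 1 to compound 3 (0.02 log units; within the scatter).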

Compound 3, half-maximal inhibitory concentration: 2600 nM
Beside the measured number, compound 3's estimate is 1.5-fold (0.19 log units) above it, and the stated range covers the measured number.
By their numbers in this assay, from the lowest: compounds 3, 1 and 2 (each within the scatter of the next).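

In this assay, placing methoxy on an aromatic carbon, ortho to a large group, gives a 1.6-fold lower number from compound 1 to compound 3 (0.21 log units; within the scatter) and so does not move the number beyond the usual scatter. Compound 3 adds a second kind of group on this aromatic ring after the nitro of compound 2, and for these two changes, the only ones on this ring so far, neither step lies beyond the scatter, so the ring has tolerated both in this assay. No measurement available here explains this result.

Going by these compounds, it remains open whether a group on the same carbon could shift the number beyond the scatter, for example a hydroxyl, an amine or a longer chain joined through oxygen. On these data alone, the effect of methoxy on the other carbons of this ring also remains open.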